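The source may hold more compounds than are shown below. What is called first, only, known or untested is meant among the compounds shown, and "the series" means these compounds.

Compound 1 `C/C(=N\OCC(=O)Nc1ccccc1)C1=C(O)c2ccccc2S(=O)(=O)N1C`, compound 2 `COc1cccc(NC(=O)CO/N=C(\C)C2=C(O)c3ccccc3S(=O)(=O)N2C)c1`, compound 3 `C/C(=N\OCC(=O)Nc1ccc(F)c(Cl)c1)C1=C(O)c2ccccc2S(=O)(=O)N1C`.

In a functional assay on THP-1 cells (Homo sapiens) for inhibition, read by ELISA, with stated times of 2 h and 48 h (on this read-out higher numbers stand for weaker inhibition and lower numbers for stronger inhibition), compound 1 gives > 20000 nM, which is a limit of the assay rather than a number. Compound 2 gives > 20000 nM in this assay, again a limit. Compound 3 gives > 20000 nM in this assay, also a limit. Compound 3 thus stands at the limit of > 20000 nM in this assay, at which 3 of the 3 values shown sit. The steps a step that the two limits leave unreadable from compound 1 to compound 2, a step that the two limits leave unreadable from compound 1 to compound 3 and a step that the two limits leave unreadable from compound 2 to compound 3 therefore have no readable size. Compound 4 `C/C(=N\OCC(=O)Nc1c(F)cccc1F)C1=C(O)c2ccccc2S(=O)(=O)N1C` differs from compound 3 by 2,6-difluorophenyl in place of 3-chloro-4-fluorophenyl on an amide-type nitrogen. The measured steps bear on this change only by showing that two other groups on the amide-type nitrogen left the limit unmoved. Compound 4 is expected to remain at the limit, so the step that the limit leaves unreadable from compound 3 to compound 4 is expected to be none beyond the scatter. For compound 4 the estimate is 30000 nM, from 10000 nM to 100000 nM.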

Compound 4, half-maximal inhibitory concentration: > 20000 nM
Compound 4: only a limit was reported; the forecaster's own chance of this, stated with the estimate: 85%; the middle value does not contradict the limit.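

Compound 4 stays at the limit, as do compound 1, compound 2 and compound 3, so no step among them can be read in this assay: the limit of > 20000 nM in this assay, at which 4 of the 4 values shown sit.

The compounds shown leave open how strongly any of them inhibits, and whether the group on the amide-type nitrogen matters at all.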